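Trifluoromethyl in place of phenyl: a small step expected

A few compounds are considered here, and "the series" means these few. Any claim that something is new, unique, unknown or untested is made for them only; others in the source may bear on it.

In a functional assay on CCRF-CEM cells (Homo sapiens) for inhibition, read by sulforhodamine B assay, with a stated time of 48 h, tested at 10 uM (on this read-out higher numbers stand for more inhibition of growth at the one concentration tested and lower numbers for less inhibition of growth), three compounds have been read so far. Compound 1 (`CC(=O)c1cccc(Nc2ccnc(SCC(=O)c3ccc(-c4ccccc4)cc3)n2)c1`) gives 28% while compound 2 (`CC(=O)c1ccc(Nc2ccnc(SCC(=O)c3ccc(Cl)cc3)n2)cc1`) gives 29% and compound 3 (`CC(=O)c1ccc(Nc2ccnc(SCC(=O)c3ccc(-c4ccccc4)cc3)n2)cc1`) gives 22% in the same read-out. Compound 1 thus stands level with both others within the scatter.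

Compound 4 (`CC(=O)c1cccc(Nc2ccnc(SCC(=O)c3ccc(C(F)(F)F)cc3)n2)c1`) keeps the 3-acetylphenyl group of compound 1 and carries trifluoromethyl in place of phenyl on an aromatic carbon. For the measured compounds named here, two measured steps bear on this change. Exchanging chloro for phenyl at that same place gave a small shift (a number 7 percentage points lower from compound 2 to compound 3 (within the scatter)) and exchanging 3-acetylphenyl for 4-acetylphenyl gave another (a number 6 percentage points lower from compound 1 to compound 3 (within the scatter)). Going by the values given here, both lie within the scatter, although no compound carrying trifluoromethyl has yet been measured, so this guide is indirect. In this assay the expected step is no change at the digits printed from compound 1 to compound 4 (within the scatter) (nothing beyond the scatter and no direction favoured). For compound 4 the estimated value is 28% (expected range 15% to 42%).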

Compound 4, percent growth inhibition at one concentration: 10%
Beside the measured number, compound 4's estimate is 18 percentage points above it; the measured number lies below the stated range.
By their numbers in this assay, from the lowest: compound 4; then compounds 3, 1 and 2 (each within the scatter of the next).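

With the 3-acetylphenyl group kept, trifluoromethyl in place of phenyl on this aromatic carbon, para to a large group, gives a number 18 percentage points lower from compound 1 to compound 4 (beyond the scatter) in this assay. For the compounds shown here, this is the first step beyond the scatter; the earlier exchange of chloro for phenyl at this place stayed within it, so the group here can affect the read-out after all. No available evidence explains the lower number. The compounds shown leave open whether trifluoromethyl would bring the same step alongside 4-acetylphenyl, and so whether this step belongs to the group alone or to its pairing with 3-acetylphenyl. They also leave open how an amine, a methoxy group or a carboxylic acid at this place would read.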